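Sulfur to Selenium at the Imine Carbon of Compound 1

The source may report more compounds than this note shows. Statements on the series, on what has been measured and on what is new or still open speak of the compounds shown alone.

The series was tested in a functional assay on K562 cells (Homo sapiens) for cytotoxicity, read by MTT assay, with a stated time of 72 h; on this read-out lower numbers stand for stronger inhibition of growth and higher numbers for weaker inhibition of growth. Compound 1 `CS/C(=N\C(=O)c1csc([N+](=O)[O-])c1)NC(=O)c1csc([N+](=O)[O-])c1` gives 98700 nM in this assay, the highest of the two numbers available. The nearest number belongs to compound 3 `O=C(/N=C(/NC(=O)c1ccco1)[Se]Cc1ccccc1)c1ccco1`, which gives 44200 nM in this assay, a gap that lies beyond the usual scatter. Compound 2 `CS/C(=N\C(=O)c1cccs1)NC(=O)c1cccs1` reaches only a limit of the assay, > 100000 nM in this assay, and sits at the limit of > 100000 nM in this assay, at which 1 of the 3 values shown sits. Among the compounds with values here, no pair of measured compounds differs in a single place, so no measured step exists for comparison. Compound 4 `C[Se]/C(=N\C(=O)c1csc([N+](=O)[O-])c1)NC(=O)c1csc([N+](=O)[O-])c1` departs from compound 1 by a group of 2 heavy atoms (1 carbon, 1 selenium; no ring) in place of a group of 2 heavy atoms (1 carbon, 1 sulfur; no ring), on a carbon with a double bond to nitrogen, a change at the carbon with a double bond to nitrogen whose other neighbours are two amide-type nitrogens. Within the data shown here, with no measured step to lean on, the expected change from compound 1 to compound 4 in this assay is a 1.3-fold lower number from compound 1 to compound 4 (0.12 log units; within the scatter), a small shift that may not exceed the scatter. Compound 4 is therefore estimated at 75000 nM in this assay, within a range from 25000 nM to 150000 nM.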

Compound 4, concentration for total growth inhibition: > 100000 nM
Compound 4 ended at the assay's limit; the forecaster's own chance of this, stated with the estimate: 30%; middle value at least 1.3-fold (0.12 log units) away from the limit.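

Within the data shown here, the exchange of methylsulfanyl for the selenium group, on a carbon with a double bond to nitrogen, gives the first measured step at this position in this assay: an at least 1.0-fold higher number from compound 1 to compound 4 (0.00 log units; that floor lies within the scatter). Compound 4 gives > 100000 nM, which is a limit of the assay, so the step sets only a floor and does not show how far the two compounds lie apart. On the core of compound 1 the exchange brings no lower number, and the read-out leaves little room at this end of the range: the limit of > 100000 nM in this assay, at which 2 of the 4 values shown sit.

The compounds shown leave open whether a longer chain on the selenium, or an amine in its place on this carbon, would lower the number of compound 1. They also leave open how the same exchange would read on a core whose values lie clear of the limit.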